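The source may report more compounds than this note shows. Statements on the series, on what has been measured and on what is new or still open speak of the compounds shown alone.

Measured compounds in a functional assay on the whole organism (strain Charles-Foster albino) for inhibition, with Rattus norvegicus as the target, read by paw edema, at a dose of 50 mg/kg by the oral route; on this read-out higher numbers stand for more inhibition at the one dose given (going by the name of the read-out) and lower numbers for less inhibition:
compound 1 `COc1ccc(C2SCC(=O)N2n2c(CSc3nnc(-c4ccncc4)o3)nc3ccc(Br)cc3c2=O)cc1` gives 35.3%
compound 2 `O=C1CSC(c2ccccc2)N1n1c(CSc2nnc(-c3ccncc3)o2)nc2ccccc2c1=O` gives 30.1%
compound 3 `O=C1CSC(c2ccccc2)N1n1c(CSc2nnc(-c3ccncc3)o2)nc2ccc(Br)cc2c1=O` gives 31.3%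

Compound 3 stands second highest of the three numbers in this assay. Its nearest neighbour is compound 2, and the gap between them is within the scatter; the gap to compound 1, the furthest of the three, is within the scatter as well. The two measured steps are a number 4 percentage points lower from compound 1 to compound 3 (within the scatter) and a number 1.2 percentage points higher from compound 2 to compound 3 (within the scatter); both lie within the scatter, so the three measured compounds are not separated in this assay by anything beyond repeat variation.

Compound 4 `O=c1c2cc(Br)ccc2nc(CSc2nnc(-c3ccncc3)o2)n1/N=C/c1ccccc1` has not yet been measured. It differs from compound 3 in one place: a group of 8 heavy atoms (7 carbon, 1 nitrogen; one six-membered aromatic ring of carbon only) in place of a group of 12 heavy atoms (9 carbon, 1 nitrogen, 1 oxygen, 1 sulfur; one five-membered non-aromatic ring with 2 hetero atoms, one six-membered aromatic ring of carbon only), on an aromatic nitrogen. Neither measured step concerns this position; both exchange a substituent on an aromatic carbon, and so neither bears directly on the exchange on the aromatic nitrogen. The data give no direction for this change. The three measured compounds sit in a narrow band in this assay, and for compound 4 the expected step is a number 0.3 percentage points lower from compound 3 to compound 4 (within the scatter), none beyond the scatter. Compound 4 is therefore estimated at 31% in this assay, with a range from 20% to 42%.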

Compound 4, a percentage reported as inhibition, in the whole organism at one dose (the size of the read-out at that dose, not a potency): 19.4%
Compound 4: middle estimate off by 11.6 percentage points, on the high side; the whole stated range lies above it.
By their numbers in this assay, from the lowest: compound 4; then compounds 2, 3 and 1 (each within the scatter of the next).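

In this assay the exchange on the aromatic nitrogen gives a number 11.9 percentage points lower from compound 3 to compound 4 (beyond the scatter) and is the only step among the compounds shown that lies beyond the scatter. The two earlier steps both concerned a substituent on an aromatic carbon and stayed within the scatter, so this is the first position shown at which the read-out answers to a change. Both groups carry a six-membered aromatic ring of carbon only, so the five-membered non-aromatic ring with 2 hetero atoms in the 4-oxo-2-phenyl-1,3-thiazolidin-3-yl group is what leaves with the exchange, although this single pair does not show that its loss accounts for the step. No measurement shown explains why the number falls with this exchange.

The compounds shown leave open whether the same step would appear without the bromo substituent or with the methoxy group of compound 1, as the exchange is seen in one pair only. They also leave open how this assay would respond to a dimethylamino group or a carboxylic acid on the aromatic ring of the group entering at this position.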